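This account rests on a few compounds, and the source may have more. Where it says the series, first, only, none or still open, it means among the compounds named here.

In a functional assay on the whole organism (B cells) with Mus musculus as the target (a lower number here means a smaller maximal response, a higher number a larger maximal response), compound 2, `CCCCCCCCCCn1c(=O)n(C2OC(CO)[C@@H](O)[C@H]2O)c2nc(N)nc(O)c21`, gives 0%, the lowest of the two numbers recorded, with compound 1, `C=CCn1/c(=N\C#N)n([C@H]2OC(CO)[C@@H](O)[C@H]2O)c2cc(N)nc(O)c21`, giving 85% in this assay, a gap beyond the scatter. Compound 3, `Nc1nc(O)c2c(n1)n(C1OC(CO)[C@@H](O)[C@H]1O)c(=O)n2CCN1CCCCC1`, has not yet been measured; it differs from compound 2 by piperidin-1-yl in place of octyl on a saturated chain carbon, two bonds along the chain from an aromatic nitrogen. Within the data shown here, no step between two measured compounds isolates such a change, so the direction rests on compound 2 alone. The step of a number 35 percentage points higher from compound 2 to compound 3 (beyond the scatter) is expected to be upward but uncertain. Compound 3 is estimated to give 35% in this assay, within 0% to 80%.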

Compound 3, largest response reached (reported as maximal response), in percent of the reference or control that the assay uses: 0%
Compound 3: the middle estimate sits 35 percentage points above what was measured; low and high end bracket the measured number.
By their numbers in this assay, from the lowest: compounds 2 and 3 (each within the scatter of the next); then compound 1.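

In this assay, piperidin-1-yl in place of octyl, on a saturated chain carbon two bonds along the chain from an aromatic nitrogen, gives no change at the digits printed from compound 2 to compound 3 (within the scatter). At this position, the decyl chain and the 2-(piperidin-1-yl)ethyl group therefore cannot be told apart in this read-out. No evidence is available to explain this result.

As far as these compounds go, whether a shorter chain, a carboxylic acid or a primary amine at this position would read differently remains open. Compound 1 differs in several places, so which of them goes with its 85% also stays unresolved.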